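This account rests on a few compounds, and the source may have more. Where it says the series, first, only, none or still open, it means among the compounds named here.

- compound 1 `Cc1nnc(NC(=O)/C(C#N)=C/c2cccc(OS(C)(=O)=O)c2)s1`: 20%
- compound 2 `COc1ccccc1-c1nnc(NC(=O)/C(C#N)=C/c2cccc(OS(=O)(=O)c3ccc(C)cc3)c2)s1`: 73%
- compound 3 `COc1ccc(Cc2nnc(NC(=O)/C(C#N)=C/c3ccccc3OS(=O)(=O)c3ccc(OC)cc3)s2)cc1`: 100%

In a functional assay on HL-60 cells (Homo sapiens) for inhibition, read by CCK-8 assay, with a stated time of 48 h, tested at 20 uM (on this read-out higher numbers stand for more inhibition of growth at the one concentration tested and lower numbers for less inhibition of growth), compound 3 gives 100%, the highest of the three numbers, and its gaps to compound 2 and compound 1 both lie beyond the scatter. Compound 4 `COc1ccc(Cc2nnc(NC(=O)/C(C#N)=C/c3ccccc3OS(=O)(=O)c3ccc(F)cc3)s2)cc1` differs from compound 3 in one place, with fluoro in place of methoxy on an aromatic carbon, para to a large group (fluoro in place of methoxy on an aromatic carbon). Within the data shown here, no measured pair shows this change on its own, so the data offer no direct guide. Compound 3 stands at 100%, which leaves little room upward. The expected change in this assay is a modest downward step, a number 10 percentage points lower from compound 3 to compound 4 (within the scatter). For compound 4 the estimated value is 90%, within an expected range of 65% to 100%.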

Compound 4, percent growth inhibition at one concentration: 25%
The estimate for compound 4 lay 65 percentage points above the measured number; measured number outside the range, below it.
By their numbers in this assay, from the lowest: compounds 1 and 4 (each within the scatter of the next); then compound 2; then compound 3.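

In this assay the change from methoxy to fluoro gives a large drop (a number 75 percentage points lower from compound 3 to compound 4 (beyond the scatter)), so growth inhibition depends strongly on the group at this place, para to a large group. The earlier compounds shown here differ in several places at once and could not isolate this single position. The data offer no explanation for the size of this drop.

Going by these compounds, it remains open whether an amine or a longer chain such as ethoxy at this place would retain the inhibition. It is also unclear whether the same change would have a similar effect in another compound.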